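Swapping one sulfonyl group in a rat whole-organism assay

This account rests on a few compounds, and the source may have more. Where it says the series, first, only, none or still open, it means among the compounds named here.

Compound 1 `CSc1cc(C)nc(Cl)c1NC(=O)N(Cc1ccc(Oc2ccc(F)cc2)cc1)C1CCCCCC1`: 0.022 mg/kg
Compound 2 `Cc1cc(S(C)(=O)=O)c(NC(=O)N(Cc2ccc(Oc3ccc(F)cc3)cc2)C2CCCCCC2)c(S(C)(=O)=O)n1`: 0.068 mg/kg

Of the compounds shown here, two with a shared fluorophenoxy-bearing side have so far been tested in a functional assay on the whole organism with Rattus norvegicus as the target; a lower number here means that less compound is needed, a higher number that more compound is needed for the effect. Compound 2, at 0.068 mg/kg, has the higher number of the two, so more of it is needed for the effect. Compound 1 gives 0.022 mg/kg, and the gap between them lies beyond the usual scatter.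

The next compound is compound 3 `CSc1cc(C)nc(S(C)(=O)=O)c1NC(=O)N(Cc1ccc(Oc2ccc(F)cc2)cc1)C1CCCCCC1`, still to be measured in this assay. It is reached from compound 2 with methylsulfanyl in place of methylsulfonyl on an aromatic carbon, opposite the ring nitrogen: methylsulfanyl in place of methylsulfonyl on an aromatic carbon. Its other methylsulfonyl group stays. Going by the values given here, no measured pair isolates this change, so the expectation rests on two values only. Compound 1, which also carries methylsulfanyl, gives 0.022 mg/kg, and this points toward a lower number than that of compound 2. A small move in that direction is expected, and the estimated step of a 1.7-fold lower number from compound 2 to compound 3 (0.23 log units; within the scatter) may not clear the scatter. For compound 3 the estimated value is 0.04 mg/kg, with an expected range from 0.015 mg/kg to 0.11 mg/kg.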

Compound 3, dose for half-maximal effect: > 0.1 mg/kg
Compound 3: only a limit was reported; the forecaster's own chance of this, stated with the estimate: 2%; middle value at least 2.5-fold (0.39 log units) away from the limit.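

Going by these compounds alone, the reading for compound 3 in this assay is a limit and not a number: the limit of > 0.1 mg/kg in this assay, at which 1 of the 3 values shown sits. Methylsulfanyl in place of methylsulfonyl on the aromatic carbon opposite the ring nitrogen gives an at least 1.4-fold higher number from compound 2 to compound 3 (0.16 log units; that floor lies within the scatter), so with the other methylsulfonyl group kept, this change does not lower the number, a point that no earlier pair could settle. Methylsulfonyl in place of chloro gives an at least 4.5-fold higher number from compound 1 to compound 3 (0.65 log units; beyond the scatter), which shows that methylsulfanyl alone does not carry the low number of compound 1: with methylsulfanyl present in both compounds, the exchange of chloro for methylsulfonyl clearly raises the number.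

As far as these compounds go, how far compound 3 lies beyond its limit remains unknown, so the full size of both steps stays open, and so does whether the step from compound 2 is larger than the usual scatter. The compounds shown also leave open whether a methoxy group, an amine or a fluoro group in place of the chloro of compound 1 would keep the number low with methylsulfanyl in place.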